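Methoxy on a second core: notes toward compound 4

The source may report more compounds than this note shows. Statements on the series, on what has been measured and on what is new or still open speak of the compounds shown alone.

Compound 1 `COc1ccc2[nH]cc(/C=C(\C#N)C(=O)c3c[nH]c4ccccc34)c2c1` is the starting point of the pair. In a functional assay on PC-3 cells (Homo sapiens) for cytotoxicity, read by WST assay, with a stated time of 48 h (on this read-out lower numbers stand for stronger inhibition and higher numbers for weaker inhibition), compound 1 gives 30500 nM. Compound 2 `COc1ccc2[nH]cc(/C=C(\C#N)C(=O)c3c[nH]c4ccc(OC)cc34)c2c1` differs from it by one change: methoxy in place of hydrogen on an aromatic carbon. Compound 2 returns only a limit of this assay, > 50000 nM. The step is an at least 1.6-fold higher number from compound 1 to compound 2 (0.21 log units; that floor lies within the scatter); its floor follows from the limit of > 50000 nM in this assay, at which 2 of the 3 values shown sit.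

Compound 3 `N#C/C(=C\c1c[nH]c2cc(F)ccc12)C(=O)c1c[nH]c2ccccc12` rests on another core; the difference between the two cores of compound 1 and compound 3 is not broken down here. In this assay compound 3 likewise returns only a limit, > 50000 nM.

Compound 4 `COc1ccc2c(C(=O)/C(C#N)=C/c3c[nH]c4cc(F)ccc34)c[nH]c2c1` is still to be measured in this assay and arises from compound 3 by the same change: methoxy in place of hydrogen on an aromatic carbon. Within the data shown here, both places are described in identical words, so the change is the same as the one from compound 1 to compound 2. The step expected here is a step that the limit leaves unreadable from compound 3 to compound 4, set beside the earlier one. That expectation rests on the measured step of an at least 1.6-fold higher number from compound 1 to compound 2 (0.21 log units; that floor lies within the scatter) and on compound 3 already sitting at the limit. Compound 4 is estimated at 80000 nM, within 40000 nM to 200000 nM, most probably reported only as a limit.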

Compound 4, half-maximal inhibitory concentration: 22500 nM
Beside the measured number, compound 4's estimate is 3.6-fold (0.55 log units) above it; measured number outside the range, below it.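

On the core of compound 3, methoxy in place of hydrogen on an aromatic carbon gives an at least 2.2-fold lower number from compound 3 to compound 4 (0.34 log units; beyond the scatter) in this assay. The change therefore does not carry from one core to the other in this series with a single direction or size: the same change on two cores in this assay, an at least 1.6-fold higher number (0.21 log units; that floor lies within the scatter) from compound 1 to compound 2 and an at least 2.2-fold lower number (0.34 log units; beyond the scatter) from compound 3 to compound 4, at least 3.6-fold (0.56 log units) apart, beyond the scatter of two such steps. Among these compounds, each core offers only one pair, so this shows that the outcome can depend on the core but gives neither a rule for other cores, nor a reason for the gap, nor the full size of either step, whose reading is bounded by a limit of the assay: the limit of > 50000 nM in this assay, at which 2 of the 4 values shown sit.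

On these data alone, it remains open how other groups on the same aromatic carbon of the core of compound 3 would read, such as an amine, a carboxylic acid or a longer chain like ethoxy. Also open, as far as these compounds go, is whether a second methoxy pair on either core would follow the step seen on that core.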